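Hydroxy to ethyl on the sulfonamide chain

The source may hold more compounds than are shown below. What is called first, only, known or untested is meant among the compounds shown, and "the series" means these compounds.

Three compounds have numbers in an assay for inhibition of serine/threonine-protein kinase PLK2 (Homo sapiens), read by FRET and Z'-LYTE, with a stated time of 1 h; on this read-out lower numbers stand for stronger inhibition and higher numbers for weaker inhibition. Compound 1 `CCC1C(=O)N(C)c2cnc(-n3ccc4cc(C(N)=O)ccc43)nc2N1c1ccn(C)n1` gives 384 nM in this assay, compound 3 `CCC1C(=O)N(C)c2cnc(Nc3ccc(S(=O)(=O)NCCCO)cc3)nc2N1c1ccn(C)n1` gives 192 nM, and compound 2 `CC[C@@H]1C(=O)N(C)c2cnc(Nc3ccc(S(=O)(=O)NCCO)cc3)nc2N1C1CCCC1` gives 7.86 nM. Compound 2 stands lowest of the three: compound 3 sits nearest, beyond the scatter, and compound 1 sits furthest, also beyond the scatter. Compound 4 `CCCCNS(=O)(=O)c1ccc(Nc2ncc3c(n2)N(C2CCCC2)[C@H](CC)C(=O)N3C)cc1` has not been measured in this assay. It differs from compound 2 in one place (ethyl in place of hydroxy on a saturated chain carbon, two bonds along the chain from a sulfonamide nitrogen). Going by the values given here, no pair of measured compounds differs in a single place, so no measured step in this assay is known for the series, and nothing measured speaks directly to this exchange. The expected step is a 1.5-fold higher number from compound 2 to compound 4 (0.18 log units; within the scatter), a modest weakening, at the edge of the scatter rather than clearly beyond it. In this assay compound 4 is expected to give 12 nM, in the range 4 nM to 35 nM.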

Compound 4, half-maximal inhibitory concentration: 19.9 nM
For compound 4 the middle estimate is 1.7-fold (0.22 log units) below the measured one; the range from low to high includes it.
By their numbers in this assay, from the lowest: compound 2; then compound 4; then compounds 3 and 1 (each within the scatter of the next).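

In this assay, going by these compounds alone, the exchange of hydroxy for ethyl gives the first single-place step, a 2.5-fold higher number from compound 2 to compound 4 (0.40 log units; beyond the scatter) that is modest but beyond the scatter. The hydroxy group is therefore not needed for activity at this position, since compound 4 still reads 19.9 nM in the absence of the hydrogen-bond donor and acceptor that hydroxy carries. Nothing measured here accounts for the size of this step.

Because hydroxy leaves and ethyl enters in a single exchange, the compounds shown do not separate the loss of the hydroxy group from the gain in chain length. Also open, on these data alone, is how a 2-aminoethyl group, a propyl chain or a pentyl chain in place of 2-hydroxyethyl would read in this assay on this scaffold.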